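This account rests on a few compounds, and the source may have more. Where it says the series, first, only, none or still open, it means among the compounds named here.

Measured compounds:

Compound 1 `Cc1cccc(-c2nc(CNc3ccc(C(=O)NO)cc3)n(-c3ccccc3)n2)c1`; in an assay on Sf9 cells for inhibition of protein deacetylase HDAC6 (Homo sapiens), read by fluorescence, with a stated time of 40 min (a higher number here means a weaker inhibitor, a lower number a stronger inhibitor), compound 1 gives 281 nM.
Compound 2 `COc1ccc(-c2nc(CNc3ccc(C(=O)NO)cc3)n(-c3ccccc3)n2)cc1`; compound 2 gives 163 nM.
Compound 3 `O=C(NO)c1ccc(NCc2nc(-c3ccccc3)nn2-c2ccccc2Cl)cc1`; compound 3 gives 669 nM.

Compound 2 has the lowest of the three numbers, but its gap to compound 1 is within the scatter, so the two cannot be ranked against each other; only compound 3, whose phenyl ring on the triazole nitrogen carries a chlorine, stands beyond the scatter from compound 2. Among the compounds with values here, the one measured step, a 1.7-fold lower number from compound 1 to compound 2 (0.24 log units; within the scatter), shows that swapping one substituent pattern on the pendant phenyl ring for another moves the number only within the scatter.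

Compound 4 `O=C(NO)c1ccc(NCc2nc(-c3ccccc3)nn2-c2ccccc2)cc1` differs from compound 2 by hydrogen in place of methoxy on an aromatic carbon. Within the data shown here, no measured step removes a substituent from this ring outright, so the expectation leans on the step from compound 1 to compound 2 alone, which was small. The step of a 1.5-fold higher number from compound 2 to compound 4 (0.19 log units; within the scatter) is therefore expected to be small, most likely a slight rise in the number, but not beyond the scatter. Compound 4 is estimated at 250 nM, with a likely range from 110 nM to 560 nM.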

Compound 4, half-maximal inhibitory concentration: 112 nM
Beside the measured number, compound 4's estimate is 2.2-fold (0.35 log units) above it; low and high end bracket the measured number.
By their numbers in this assay, from the lowest: compounds 4, 2 and 1 (each within the scatter of the next, the first and the last beyond it); then compound 3.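

With the 4-methoxyphenyl changed to phenyl, the step is a 1.5-fold lower number from compound 2 to compound 4 (0.16 log units; within the scatter), so on this aromatic carbon the methoxy group can be removed without a change that stands beyond the scatter. Two further one-place comparisons go beyond what the earlier compounds showed: hydrogen in place of methyl gives a 2.5-fold lower number from compound 1 to compound 4 (0.40 log units; beyond the scatter) and hydrogen in place of chloro gives a 6.0-fold lower number from compound 3 to compound 4 (0.78 log units; beyond the scatter), so among these compounds neither the methyl nor the chloro group is needed, and the unsubstituted compound 4 has a lower number than the compounds carrying them. Nothing available here bears on the reason for these steps.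

On these data alone, whether an amine, a hydroxyl or a carboxylic acid on the same aromatic carbon would lower the number beyond the scatter remains open. So does whether a fluoro group in place of the chloro group would give a step of similar size.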